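A few compounds are considered here, and "the series" means these few. Any claim that something is new, unique, unknown or untested is made for them only; others in the source may bear on it.

Measured so far:
compound 1 `COc1c(C)cnc(CNc2ccc3c(c2)nc(C)n3C[C@@H](O)[C@H]2O[C@H](O)[C@@H](O)[C@H]2O)c1C` — 36%
compound 2 `Cc1nc2cc(NCc3ccccn3)ccc2[nH]1` — 10%

In a functional assay on the whole organism (strain Sprague-Dawley) for inhibition, with Rattus norvegicus as the target, read by paw edema, with a stated time of 180 min, at a dose of 10 mg/kg by the oral route (a lower number here means a weaker effect, a higher number a stronger effect of the compound at the dose given), compound 1 gives 36%, the higher of the two numbers, while compound 2 gives 10%; the gap between them lies beyond the usual scatter of such measurements. Going by the values given here, no two measured compounds differ in just one place, so no single step can be read off directly.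

Compound 3 `Cc1nc2cc(NCc3ccccn3)ccc2n1C[C@@H](O)[C@H]1O[C@H](O)[C@@H](O)[C@H]1O` is the compound that follows from compound 1 through one change: pyridin-2-yl in place of 4-methoxy-3,5-dimethylpyridin-2-yl on a saturated chain carbon bound to a nitrogen on an aromatic ring. Among the compounds with values here, the only guide to this change is that compound 2, which also carries a plain pyridin-2-yl group, stands well below compound 1 in this assay.

In this assay a step downward is therefore expected, of moderate size and reaching beyond the scatter, a number 14 percentage points lower from compound 1 to compound 3 (beyond the scatter). Compound 3 is accordingly estimated at 22%, within a range from 8% to 38%.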

Compound 3, a percentage reported as inhibition, in the whole organism at one dose (the size of the read-out at that dose, not a potency): 8%
Compound 3: the middle estimate sits 14 percentage points above what was measured; the measured number falls inside the stated range.
By their numbers in this assay, from the lowest: compounds 3 and 2 (each within the scatter of the next); then compound 1.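

In this assay, going by these compounds alone, pyridin-2-yl in place of 4-methoxy-3,5-dimethylpyridin-2-yl on a saturated chain carbon bound to a nitrogen on an aromatic ring gives a number 28 percentage points lower from compound 1 to compound 3 (beyond the scatter) and is the first direct reading of this change, with the rest of the structure held constant. With pyridin-2-yl in this place, compound 3 gives 8% and compound 2 gives 10%, two numbers within the scatter of each other, so the added side chain of compound 3 brings no separation from compound 2 here. Nothing measured here explains the step.

As far as these compounds go, the methoxy group and the two methyl groups leave together, so the share of each remains open. Also open, from the compounds shown here alone, is whether an amine or a carboxylic acid in place of the methoxy group would retain the effect of compound 1.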